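This account rests on a few compounds, and the source may have more. Where it says the series, first, only, none or still open, it means among the compounds named here.

In an ADME assay on L1210/0 cells (Mus musculus) for cytotoxicity, with a stated time of 48 h (on this read-out higher numbers stand for weaker inhibition and lower numbers for stronger inhibition), three structurally dissimilar compounds have been measured. Compound 1 `CC1(C)[C@H](CCO)C[C@@H]1n1cnc2c(Cl)nc(N)nc21` gives 105000 nM, compound 2 `COC1=C(OCc2ccc([N+](=O)[O-])cc2)/C(=C/CN2CNc3c(Cl)ncnc32)OC1=O` gives 13100 nM, and compound 3 `O=c1[nH]c(=O)n([C@H]2C[C@H](O)[C@@H](CO)O2)cc1/C=C/I` gives 63900 nM. Compound 3 stands within the scatter of compound 1, so these two are not separated here. The number for compound 3 lies above that of compound 2, and this gap is beyond the scatter. Within the data shown here, all three numbers are high on this scale, and none of the three pairs differs in only one place, so the series offers no measured step for calibration.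

The next compound is compound 4 `[N-]=[N+]=NCc1cn([C@H]2C[C@H](O)[C@@H](CO)O2)c(=O)[nH]c1=O`, which keeps the core of compound 3 and changes one substituent: azidomethyl in place of 2-iodoethenyl on an aromatic carbon. In words, azidomethyl takes the place of 2-iodoethenyl on an aromatic carbon.

Compound 3 at 63900 nM is the only measured anchor with this core, so the expectation starts from that value and carries wide uncertainty. In this assay the expected change is a 2.1-fold lower number from compound 3 to compound 4 (0.33 log units; beyond the scatter), a modest move toward a lower number and stronger inhibition, close to the edge of the scatter. For compound 4 the estimated value is 30000 nM, with an expected range of 6000 nM to 150000 nM.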

Compound 4, half-maximal inhibitory concentration: 124000 nM
Estimate against measurement, compound 4: 4.1-fold (0.62 log units) below; low and high end bracket the measured number.
By their numbers in this assay, from the lowest: compound 2; then compounds 3, 1 and 4 (each within the scatter of the next).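

In this assay, among these compounds, the first measured step reads a 1.9-fold higher number from compound 3 to compound 4 (0.29 log units; within the scatter), and azidomethyl in place of 2-iodoethenyl on an aromatic carbon therefore does not separate the two compounds. At this place, on a six-membered aromatic ring with 2 nitrogen, a group of carbon and iodine gives way to one of carbon and nitrogen, neither with a ring, and the read-out shows no change that stands clear of the usual scatter. No measured property of either compound bears on this result, so the step stays a bare observation.

Going by these compounds, whether an amine, a carboxylic acid or a longer chain on this same aromatic carbon would give a step beyond the scatter remains open, since a single pair of groups says little about the tolerance of the position as a whole. Also open, on these data alone, is whether a change at any other place on the shared core of compound 3 and compound 4 would give a step beyond the scatter.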